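Aryl exchange on the core of compound 1

The source may hold more compounds than are shown below. What is called first, only, known or untested is meant among the compounds shown, and "the series" means these compounds.

Measured so far in a functional assay on A549 cells (Homo sapiens) for antiproliferative activity, read by MTT assay, with a stated time of 72 h (on this read-out higher numbers stand for weaker inhibition and lower numbers for stronger inhibition), are these compounds:
compound 1 `NC1=NC2(CCSCC2)N(OCCCOc2ccc(Cl)c(Cl)c2)C(N)=N1` gives 1 nM
compound 2 `NC1=NC2(CCOCC2)N(OCCCOc2ccc(F)cc2)C(N)=N1` gives 1060 nM
compound 3 `NC1=NC2(CCOCC2)N(OCCCOc2ccc(Cl)c(Cl)c2)C(N)=N1` gives 790 nM

Compound 1 has the lowest of the three numbers and lies beyond the scatter of both others. Compound 4 `NC1=NC2(CCSCC2)N(OCCCOc2ccccc2Br)C(N)=N1` keeps the core of compound 1 and carries 2-bromophenyl in place of 3,4-dichlorophenyl (2-bromophenyl in place of 3,4-dichlorophenyl on an oxygen on a saturated carbon). For the measured compounds named here, the only measured exchange of this group (a 1.3-fold lower number from compound 2 to compound 3 (0.13 log units; within the scatter)) lies within the scatter. Going by the values given here, that step sits on the different core of compound 2 and compound 3, and no 2-bromophenyl compound has been measured. The estimated step is therefore modest, towards a higher number in this assay and with wide uncertainty (an 8.0-fold higher number from compound 1 to compound 4 (0.90 log units; beyond the scatter)). For compound 4 the expected value is 8 nM (estimated range 1 nM to 150 nM).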

Compound 4, half-maximal inhibitory concentration: 40 nM
For compound 4 the middle estimate is 5.0-fold (0.70 log units) below the measured one; low and high end bracket the measured number.
By their numbers in this assay, from the lowest: compound 1; then compound 4; then compounds 3 and 2 (each within the scatter of the next).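

On the core of compound 1, the aryl group on this oxygen carries real weight in this assay: 2-bromophenyl in place of 3,4-dichlorophenyl gives a large loss (a 40-fold higher number from compound 1 to compound 4 (1.60 log units; beyond the scatter)). For the compounds shown here, the only earlier exchange at this position, on the other core, stayed within the scatter (a 1.3-fold lower number from compound 2 to compound 3 (0.13 log units; within the scatter)), but it involved a different pair of groups, so no dependence on the core can be read. No evidence bears on the cause of the new step.

From the compounds shown here alone, whether the step follows from bromine or from the loss of the two chlorines stays open. 2-Chlorophenyl or unsubstituted phenyl on the core of compound 1 would help separate these.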